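Changing the aniline ring on a shared quinazoline-free core

A few compounds are considered here, and "the series" means these few. Any claim that something is new, unique, unknown or untested is made for them only; others in the source may bear on it.

Measured so far in a functional assay on A-431 cells (Homo sapiens) for antiproliferative activity, read by MTT assay, with a stated time of 72 h; a lower number here means a stronger inhibitor, a higher number a weaker inhibitor:
- compound 1, `COc1cc2ncnc(Nc3ccc(F)c(Cl)c3)c2cc1OCCCCC(=O)Nc1ccc(S(N)(=O)=O)cc1`, gives 5020 nM
- compound 2, `COc1cc2ncnc(Nc3cccc(C)c3)c2cc1OCCCCC(=O)Nc1ccc(S(N)(=O)=O)cc1`, gives 7460 nM

Among the compounds with values here, compound 2 stands next to compound 1 with no real gap between them: the only measured step, a 1.5-fold higher number from compound 1 to compound 2 (0.17 log units; within the scatter), lies within the scatter, so the two numbers cannot be told apart. Within the data shown here, that step exchanged one aryl group for another on the same nitrogen, and it is the one comparison that bears on the move to compound 3, `COc1cc2ncnc(Nc3cc(F)c(F)c(F)c3)c2cc1OCCCCC(=O)Nc1ccc(S(N)(=O)=O)cc1`. Compound 3 differs from compound 2 by 3,4,5-trifluorophenyl in place of 3-methylphenyl on a nitrogen on an aromatic ring. Since a chloro-fluoro aryl ring and a methyl aryl ring gave numbers within the scatter of each other, a trifluoro aryl ring in the same place is expected to do much the same. The step of a 1.4-fold lower number from compound 2 to compound 3 (0.13 log units; within the scatter) is therefore expected to stay within the scatter. Compound 3 is estimated at 5500 nM, within a range from 2000 nM to 15000 nM.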

Compound 3, half-maximal inhibitory concentration: 23400 nM
Beside the measured number, compound 3's estimate is 4.3-fold (0.63 log units) below it; the whole stated range lies below it.
By their numbers in this assay, from the lowest: compounds 1 and 2 (each within the scatter of the next); then compound 3.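

In this assay, the aryl group on this nitrogen proves able to shift the number after all: the earlier pair could not be told apart, whereas 3,4,5-trifluorophenyl gives a 3.1-fold higher number from compound 2 to compound 3 (0.50 log units; beyond the scatter) and a 4.7-fold higher number from compound 1 to compound 3 (0.67 log units; beyond the scatter), both modest but beyond the scatter. The change therefore points towards weaker inhibition against either earlier ring, so not every substituted aryl ring is equivalent here. Nothing available explains why this ring behaves differently.

As far as these compounds go, it remains open whether a plain phenyl ring or a 4-fluorophenyl ring would fall with compound 1 and compound 2 or with compound 3. Also open, from the compounds shown here alone, is whether the same difference between rings would persist with a shorter chain linking the shared core to its amide.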